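The source may hold more compounds than are shown below. What is called first, only, known or untested is meant among the compounds shown, and "the series" means these compounds.

Working notes on the series. In a functional assay on A549 cells (Homo sapiens) for inhibition, read by MTT assay, with a stated time of 72 h (a higher number here means a weaker inhibitor, a lower number a stronger inhibitor), compound 1 `CC1=NN(c2ccccc2)C(=O)[C@@]12C(=O)C=CC[C@@H]2c1ccccc1[N+](=O)[O-]` gives 66400 nM, compound 2 `CC1=NN(c2ccccc2)C(=O)[C@@]12C(=O)C=CC[C@@H]2c1ccc(C)cc1` gives 6570 nM and compound 3 `CC1=NN(c2ccccc2)C(=O)[C@@]12C(=O)C=CC[C@H]2c1cccc(C)c1` gives 3500 nM. Compound 3 and compound 2 lie within the scatter of each other, and both numbers are far lower than that of compound 1.

The next structure is compound 4 `CC1=NN(c2ccccc2)C(=O)[C@@]12C(=O)C=CC[C@@H]2c1cccc(C)c1`, and its relation to compound 3 is simple: the two compounds have the same atoms and bonds and differ only in configuration as drawn: 1 of 2 stereo elements differ; a stereocentre at a saturated ring carbon is drawn S in compound 3 and R in compound 4.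

Among the compounds with values here, the only measured step is a 10-fold lower number from compound 1 to compound 2 (1.00 log units; beyond the scatter). Within the data shown here, that step swaps one aryl group for another and gives no direct measure of a change in configuration, since no pair differing only in configuration has been measured in this assay. Its size therefore does not carry over.

The nearest guide is compound 2, which shares the arrangement drawn for compound 4 at the changed carbon. Compound 2 gives 6570 nM. Compound 2 differs from compound 4 in where the methyl sits on the aryl ring. This points to a small move towards a higher number, with no step beyond the scatter expected, though a larger one cannot be excluded.

The expected result is a 1.4-fold higher number from compound 3 to compound 4 (0.15 log units; within the scatter). For compound 4 the estimated value is 5000 nM, with an expected range from 1800 nM to 15000 nM.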

Compound 4, half-maximal inhibitory concentration: 4510 nM
For compound 4 the middle estimate is 1.1-fold (0.04 log units) above the measured one; the measured number falls inside the stated range.
By their numbers in this assay, from the lowest: compounds 3, 4 and 2 (each within the scatter of the next); then compound 1.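

Within the data shown here, compounds 3 and 4 give the first direct reading of configuration at this saturated ring carbon in this assay, and the comparison is a clean one: the fact that compounds 3 and 4 differ only in the configuration as drawn. The step itself, a 1.3-fold higher number from compound 3 to compound 4 (0.11 log units; within the scatter), shows no difference between S and R that can be told from the scatter, and changing 4-methylphenyl to 3-methylphenyl, a 1.5-fold lower number from compound 2 to compound 4 (0.16 log units; within the scatter), is equally unreadable. Among these compounds, the only change that registers is still the aryl swap: 3-methylphenyl in place of 2-nitrophenyl gives a 15-fold lower number from compound 1 to compound 4 (1.17 log units; beyond the scatter), in the same direction as 4-methylphenyl in place of 2-nitrophenyl, a 10-fold lower number from compound 1 to compound 2 (1.00 log units; beyond the scatter).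

On these data alone, the configuration pair covers only the 3-methylphenyl compounds, so it stays open whether the same stereocentre would matter as little with 2-nitrophenyl or 4-methylphenyl on this carbon. Also open, as far as these compounds go, is whether the higher number of compound 1 follows the nitro group itself or its place on the ring, and how an aryl group carrying an amine or a carboxylic acid would read in this assay.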